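A Larger Selenium Group on the Core of Compound 3

A few compounds are considered here, and "the series" means these few. Any claim that something is new, unique, unknown or untested is made for them only; others in the source may bear on it.

Compound 3 `CS/C(=N\C(=O)c1ccco1)NC(=O)c1ccco1` has been tested in a functional assay on MCF7 cells (Homo sapiens) for cytotoxicity, read by MTT assay, with a stated time of 72 h; on this read-out lower numbers stand for higher toxicity in this test and higher numbers for lower toxicity in this test. In this test compound 3 gives > 100000 nM, which is a limit of the assay rather than a number. Compound 1 `C[Se]/C(=N\C(=O)c1ccco1)NC(=O)c1ccco1` gives > 100000 nM in this assay, again a limit. Because (the limit of > 100000 nM in this assay, at which 2 of the 3 values shown sit), the step that the two limits leave unreadable from compound 1 to compound 3 cannot be read. Compound 2 `CS/C(=N\C(=O)c1cc2ccccc2s1)NC(=O)c1cc2ccccc2s1`, which differs in its outer parts, gives 78500 nM in this assay. Compound 4 `O=C(/N=C(/NC(=O)c1ccco1)[Se]Cc1ccccc1)c1ccco1` has not yet been measured; it carries a group of 8 heavy atoms (7 carbon, 1 selenium; one six-membered aromatic ring of carbon only) in place of a group of 2 heavy atoms (1 carbon, 1 sulfur; no ring), on a carbon with a double bond to nitrogen. Among the compounds with values here, no measured step covers this change, so no direction can be drawn from the values shown, and a limit remains a likely outcome. Compound 4 is therefore expected to give 90000 nM, ranging from 30000 nM to 300000 nM. The expected step is an at least 1.1-fold lower number from compound 3 to compound 4 (0.04 log units; that floor lies within the scatter).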

Compound 4, concentration lethal to 50% of the cells: > 100000 nM
Compound 4: a limit, no number; the forecaster's own chance of this, stated with the estimate: 55%; at least 1.1-fold (0.04 log units) between middle value and limit.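

Within the data shown here, no step among compound 1, compound 3 and compound 4 can be read, because all three stop at the same limit: the limit of > 100000 nM in this assay, at which 3 of the 4 values shown sit.

As far as these compounds go, how far these three compounds differ in toxicity in this test remains open.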